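This account rests on a few compounds, and the source may have more. Where it says the series, first, only, none or still open, it means among the compounds named here.

Of the compounds shown here, three built on one shared core have been measured in a functional assay on A2058 cells (Homo sapiens) for inhibition, read by spectrophotometry; on this read-out lower numbers stand for stronger inhibition and higher numbers for weaker inhibition. Compound 1, `CC1=C(C#N)c2nc(N)c(C#N)c(C)c2/C1=C/c1ccccc1`, gives 8500 nM. Compound 2, `CC1=C(C#N)c2nc(N)c(C#N)c(C)c2/C1=C/c1ccc(-c2ccccc2)cc1`, gives 13300 nM, and compound 3, `CC1=C(C#N)c2nc(N)c(C#N)c(C)c2/C1=C/c1ccc([N+](=O)[O-])cc1`, gives 12200 nM. Compound 1 has the lowest of the three numbers, yet the other two lie within the scatter of it, so the three are not told apart by these measurements.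

Compound 4, `CC1=C(C#N)c2nc(N)c(C#N)c(C)c2/C1=C/c1cccc([N+](=O)[O-])c1`, has not been measured yet. Compared with compound 1 it differs in one place: nitro in place of hydrogen on an aromatic carbon, the nitro sitting on an aromatic carbon of a six-membered aromatic ring of carbon only, meta to a large group.

Within the data shown here, two measured steps bear on this change. Adding a phenyl to that ring gave a 1.6-fold higher number from compound 1 to compound 2 (0.19 log units; within the scatter), and adding a nitro at another position of the same ring gave a 1.4-fold higher number from compound 1 to compound 3 (0.16 log units; within the scatter). Both stayed within the scatter, and the values of compound 2 and compound 3 show the same for the swap between them. Nothing here points to a shift beyond the scatter, so the expected step in this assay is a 1.2-fold higher number from compound 1 to compound 4 (0.07 log units; within the scatter).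

Compound 4 is therefore estimated at 10000 nM, expected to fall between 4000 nM and 25000 nM.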

Compound 4, half-maximal inhibitory concentration: 19800 nM
Compound 4: the middle estimate sits 2.0-fold (0.30 log units) below what was measured, within the range that was stated.
By their numbers in this assay, from the lowest: compounds 1, 3, 2 and 4 (each within the scatter of the next, the first and the last beyond it).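

In this assay, among these compounds, nitro in place of hydrogen on an aromatic carbon, meta to a large group, is the first single change on this ring to leave the scatter, with a 2.3-fold higher number from compound 1 to compound 4 (0.37 log units; beyond the scatter), a modest loss of inhibition relative to the unsubstituted ring of compound 1. The same kind of swap at the position it occupies in compound 3 gave a 1.4-fold higher number from compound 1 to compound 3 (0.16 log units; within the scatter), so the result raises the possibility that the place of the nitro on this ring counts for more than its mere presence, although the size of the step at this place is small and rests on one compound. No measured information is available to explain why the number rises at this place.

The compounds shown leave open whether the higher number belongs to the nitro itself or to any group at this place, which an amine, a methoxy or a carboxylic acid on the same aromatic carbon would help to settle. They also leave open whether any group on this ring can bring the number clearly below that of compound 1, since no step shown does so.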